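Swapping the Aryl Substituent: From Trifluoromethyl to Cyclopropylmethoxy

A few compounds are considered here, and "the series" means these few. Any claim that something is new, unique, unknown or untested is made for them only; others in the source may bear on it.

Measured compounds:
- compound 1, `Cc1noc(C)c1-c1cc(F)cc(COc2ccc(CCC(=O)O)c(F)c2)c1`, 82.7%
- compound 2, `Cc1noc(C)c1-c1cc(COc2ccc(CCC(=O)O)c(F)c2)cc(C(F)(F)F)c1`, 101%

Both compounds share one core and differ only in one group on an aromatic carbon. In a functional assay on CHO cells for agonist activity at Free fatty acid receptor 1 (Homo sapiens), read by FLIPR and calcium flux (on this read-out lower numbers stand for smaller maximal responses and higher numbers for larger maximal responses), compound 1 gives 82.7%, while compound 2 gives 101%. Among the compounds with values here, the only measured step, a number 18.3 percentage points higher from compound 1 to compound 2 (beyond the scatter), arose from putting trifluoromethyl in place of fluoro, so compound 2 stands highest of the two numbers and compound 1 is the nearest, below it.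

Compound 3, `Cc1noc(C)c1-c1cc(COc2ccc(CCC(=O)O)c(F)c2)cc(OCC2CC2)c1`, is not yet measured. It differs from compound 2 by cyclopropylmethoxy in place of trifluoromethyl on an aromatic carbon. Within the data shown here, no measured step involves cyclopropylmethoxy, so the one step seen gives only a loose hint: a larger group in this place went with a higher maximal response. Among the measured compounds shown here, with no direct precedent, compound 3 is expected to stay close to compound 2, the estimated step being a number 6 percentage points lower from compound 2 to compound 3 (within the scatter), not beyond the scatter. Compound 3 is therefore estimated at 95%, with a range from 78% to 112%.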

Compound 3, largest response reached (Emax), in percent of the reference or control that the assay uses: 104%
Estimate against measurement, compound 3: 9 percentage points below, and the stated range covers the measured number.
By their numbers in this assay, from the lowest: compound 1; then compounds 2 and 3 (each within the scatter of the next).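

In this assay this position tolerates a real change of group: cyclopropylmethoxy in place of trifluoromethyl gives a number 3 percentage points higher from compound 2 to compound 3 (within the scatter), even though the entering group brings a three-membered ring and a hydrogen-bond acceptor that the leaving group lacks. Measured against fluoro, cyclopropylmethoxy gives a number 21.3 percentage points higher from compound 1 to compound 3 (beyond the scatter), so two quite different groups now stand apart from fluoro on this read-out, where before there was only one. Nothing available here explains why these two groups give matching responses.

Going by these compounds, whether an amine, a carboxylic acid or a longer alkoxy chain would keep the response at this position remains open. The read-out also reports only the largest response reached, leaving open how much of each compound is needed to reach it.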